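Aryl replacement on the pyridyl ether series

A few compounds are considered here, and "the series" means these few. Any claim that something is new, unique, unknown or untested is made for them only; others in the source may bear on it.

Measured compounds:
compound 1 `CN1CCC[C@H]1COc1cncc(-c2ccccc2)c1` gives 0.11 nM
compound 2 `CN1CCC[C@H]1COc1cncc(-c2ccc(F)cc2)c1` gives 0.11 nM
compound 3 `CN1CCC[C@H]1COc1cncc(-c2ccc(F)c(Cl)c2)c1` gives 0.055 nM

In an assay on membranes from brain for binding affinity to Neuronal acetylcholine receptor; alpha4/beta2 (Rattus norvegicus) (on this read-out lower numbers stand for stronger inhibition and higher numbers for weaker inhibition), compound 2 stands level with compound 1 at the digits shown, the two together giving the highest numbers of the three; its nearest neighbour is compound 1, with no change at the digits printed from compound 1 to compound 2 (within the scatter), and its furthest is compound 3, with a 2.0-fold lower number from compound 2 to compound 3 (0.30 log units; within the scatter). Both measured steps therefore lie within the scatter.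

Compound 4 `CN1CCC[C@H]1COc1cncc(-c2ccco2)c1` has not yet been measured. It differs from compound 2 by furan-2-yl in place of 4-fluorophenyl on an aromatic carbon. For the measured compounds named here, no measured step exchanges the whole aromatic group at that carbon; the two steps on record only vary single substituents on the six-membered ring, and both left this assay essentially unchanged. Going by the values given here, that is the only guide available, and it suggests the core tolerates variation at this position while keeping very low numbers. With a smaller ring of a different kind entering, a modest weakening is plausible but not supported by any measured step, so the expected step of a 1.8-fold higher number from compound 2 to compound 4 (0.26 log units; within the scatter) is set small. Compound 4 is therefore estimated at 0.2 nM, with a range from 0.05 nM to 0.8 nM.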

Compound 4, inhibition constant: 0.19 nM
The estimate for compound 4 lay 1.1-fold (0.02 log units) above the measured number; the range from low to high includes it.
By their numbers in this assay, from the lowest: compounds 3, 1, 2 and 4 (each within the scatter of the next, the first and the last beyond it).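

In this assay, this carbon accepts an exchange of the whole aromatic group and not only of substituents on a six-membered ring: furan-2-yl in place of 4-fluorophenyl gives a 1.7-fold higher number from compound 2 to compound 4 (0.24 log units; within the scatter) and furan-2-yl in place of phenyl gives a 1.7-fold higher number from compound 1 to compound 4 (0.24 log units; within the scatter) so both exchanges stay within the scatter. The earlier compounds shown here varied only single substituents on the six-membered ring, whereas this pair shows that a five-membered aromatic ring with 1 hetero atom, carrying 5 heavy atoms and 1 hydrogen-bond acceptor against the 7 heavy atoms and 0 acceptors of 4-fluorophenyl, also leaves this assay within the scatter. Nothing measured here bears on why the exchange leaves the number within the scatter.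

Going by these compounds, it remains open whether a non-aromatic group at this carbon, such as a carboxylic acid, an aminomethyl group or a longer chain like n-butyl, would keep the numbers in this range. Also open, on these data alone, is whether a second hetero atom in the five-membered ring, as in oxazol-2-yl or thiazol-2-yl, would fit the same picture.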